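This account rests on a few compounds, and the source may have more. Where it says the series, first, only, none or still open, it means among the compounds named here.

In a functional assay on HCT-15 cells (Homo sapiens) for inhibition, read by sulforhodamine B assay, with a stated time of 48 h (a higher number here means a weaker inhibitor of growth, a lower number a stronger inhibitor of growth), compound 2 `COc1ccc(C(=O)/C=C/c2cc(-c3cc(OC)c(OC)c(OC)c3)n[nH]2)cc1` gives 1580 nM, the highest of the two numbers in hand; compound 1 `COc1ccc(C(=O)/C=C/c2cc(-c3cc(OC)c(OC)c(OC)c3)n[nH]2)cc1OC` gives 1270 nM, and the step of a 1.2-fold higher number from compound 1 to compound 2 (0.09 log units; within the scatter) stays within the scatter. Compound 3 `COc1cc(-c2cc(/C=C/C(=O)c3ccc(F)c(F)c3)[nH]n2)cc(OC)c1OC` carries 3,4-difluorophenyl in place of 4-methoxyphenyl on a carbonyl carbon. For the measured compounds named here, only the step from compound 1 to compound 2 touches the same aryl ketone part, and it was flat, so for compound 3 no step beyond the scatter is expected in this assay, though the swap is larger than a single methoxy removal. Compound 3 is estimated at 1600 nM, range 600 nM to 4500 nM, that is an expected step of a 1.0-fold higher number from compound 2 to compound 3 (0.01 log units; within the scatter).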

Compound 3, concentration for 50% growth inhibition: 3010 nM
Estimate against measurement, compound 3: 1.9-fold (0.27 log units) below, and the stated range covers the measured number.
By their numbers in this assay, from the lowest: compounds 1, 2 and 3 (each within the scatter of the next, the first and the last beyond it).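

In this assay, for the compounds shown here, an aryl ketone without methoxy appears for the first time: 3,4-difluorophenyl in place of 4-methoxyphenyl gives a 1.9-fold higher number from compound 2 to compound 3 (0.28 log units; within the scatter) and, in place of 3,4-dimethoxyphenyl, gives a 2.4-fold higher number from compound 1 to compound 3 (0.37 log units; beyond the scatter) as the first step beyond the scatter. This position on the carbonyl carbon is therefore not entirely flat, though the change is modest and only the second comparison clears the scatter. No measurement in hand accounts for this step.

Still open, from the compounds shown here alone, is whether a single fluorine, an amine or a carboxylic acid on this aryl ring would move the number further.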